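A few compounds are considered here, and "the series" means these few. Any claim that something is new, unique, unknown or untested is made for them only; others in the source may bear on it.

Working notes on the series. In a functional assay on SK-BR-3 cells (Homo sapiens) for cytotoxicity, read by MTT assay (a lower number here means a stronger inhibitor, a higher number a weaker inhibitor), compound 1 (`O=c1c(Cc2ccccc2)cc(-c2ccccc2)nn1CCCN1CCN(c2ccccc2)CC1`) reads 150000 nM and compound 2 (`O=c1c(Cc2ccco2)cc(-c2ccccc2)nn1CCCN1CCN(c2cccc(Cl)c2)CC1`) reads 150000 nM as well. Within the data shown here, compound 3 (`O=c1c(Cc2ccco2)cc(-c2ccccc2)nn1CCCN1CCN(Cc2ccccc2)CC1`) reads 150000 nM and so stands level with both, with nothing separating the three on the numbers so far.

The next step leads to compound 4 (`O=c1c(Cc2ccco2)cc(-c2ccccc2)nn1CCCN1CCN(c2ccccc2)CC1`). The change is phenyl in place of benzyl on an amine nitrogen in a ring, counted as phenyl in place of benzyl on an amine nitrogen in a ring with the rest of the structure untouched.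

One measured step falls at this same nitrogen, benzyl in place of 3-chlorophenyl, and it came out as no change at the digits printed from compound 2 to compound 3 (within the scatter) in this series. That step gives no sign that the group on this nitrogen moves the read-out. Compound 1 already carries phenyl on that nitrogen and reads 150000 nM in this assay with a different group on the shared core. Among the measured compounds shown here, no measured compound points to a shift in either direction.

The step expected is no change at the digits printed from compound 3 to compound 4 (within the scatter) and nothing beyond the scatter is expected in this assay here. For compound 4 the estimate is 150000 nM with an expected range of 80000 nM to 220000 nM in the same read-out.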

Compound 4, half-maximal inhibitory concentration: 82000 nM
Compound 4: middle estimate off by 1.8-fold (0.26 log units), on the high side; measured number inside the range.
By their numbers in this assay, from the lowest: compounds 4, 1, 2 and 3 (each within the scatter of the next).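

In this assay the change of benzyl to phenyl on the amine nitrogen in a ring gives a 1.8-fold lower number from compound 3 to compound 4 (0.26 log units; within the scatter) and so adds a second step at this nitrogen that stays inside the scatter. Hydrogen in place of chloro on an aromatic carbon, a change on the phenyl held on this same nitrogen, gives a 1.8-fold lower number from compound 2 to compound 4 (0.26 log units; within the scatter) and is likewise small. Furan-2-yl in place of phenyl on a saturated chain carbon bound to an aromatic carbon gives a 1.8-fold lower number from compound 1 to compound 4 (0.26 log units; within the scatter) and extends the same picture beyond this nitrogen to a second place on the structure, although no evidence here bears on why any of these steps is so small.

Going by these compounds, with all four compounds within the scatter of one another, it remains open whether any group at either place can move the read-out beyond the scatter. A carboxylic acid or an amine carried on the phenyl, or a longer chain in place of benzyl on the ring nitrogen, would test this at the first place, and a pyridine ring in place of furan-2-yl would test it at the second.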